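The source may report more compounds than this note shows. Statements on the series, on what has been measured and on what is new or still open speak of the compounds shown alone.

Measured compounds:
Compound 1, `COc1ccc(-c2nc(C)c(C(=O)CSc3nc(N)c(C#N)c(-c4ccccc4)n3)s2)cc1`: 61.8%
Compound 2, `Cc1nc(-c2ccccc2)sc1C(=O)CSc1nc(N)c(C#N)c(-c2ccc(Cl)cc2)n1`: 62.9%

Both compounds were tested in a functional assay on U-87MG ATCC cells for antiproliferative activity against U-87 MG (Homo sapiens), read by MTT assay, with a stated time of 48 h, tested at 5 uM; a lower number here means a stronger effect, a higher number a weaker effect of the compound at the concentration tested. Compound 2 gives 62.9%, and compound 1 stands close to it at 61.8%, a gap that lies within the scatter, so the two numbers cannot be told apart. Among the measured compounds shown here, no step between measured compounds that differ in one place is available here.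

Compound 3, `Cc1nc(-c2ccccc2)sc1C(=O)CSc1nc(N)c(C#N)c(-c2ccccc2)n1`, has not yet been measured in this assay. It differs from compound 2 by hydrogen in place of chloro on an aromatic carbon. With nothing to show what removing the chloro does, the expectation for this assay is a step of no size beyond the scatter, with the read-out for compound 3 remaining near that of compound 2.

For compound 3, the estimate in this assay is 65%, with a range from 53% to 77%. The step this implies, a number 2.1 percentage points higher from compound 2 to compound 3 (within the scatter), is expected to be small.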

Compound 3, a percentage reported as activity, at one concentration (the size of the read-out at that concentration, not a potency): 103%
For compound 3 the middle estimate is 38 percentage points below the measured one, outside the stated range (above it).
By their numbers in this assay, from the lowest: compounds 1 and 2 (each within the scatter of the next); then compound 3.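

In this assay, the change from 4-chlorophenyl to phenyl is far from silent, giving a number 40.1 percentage points higher from compound 2 to compound 3 (beyond the scatter), and hydrogen in place of methoxy gives a similar loss, a number 41.2 percentage points higher from compound 1 to compound 3 (beyond the scatter). Compound 1 and compound 2 each carry one such group, in different places on the molecule, while compound 3 carries neither, so among these three compounds an effect at the tested concentration appears only when one of the two groups is present. No measurement available here explains why these groups matter.

Still open, going by these compounds, is whether a smaller fluoro or an amino group in the place of the chloro would keep the effect. On these data alone, it is also open whether methoxy and chloro together on one molecule would strengthen it further.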